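Urea to amide in a series of pyrazole cell growth inhibitors

The source may hold more compounds than are shown below. What is called first, only, known or untested is meant among the compounds shown, and "the series" means these compounds.

Three compounds that share one core were tested in a functional assay on SR cells (Homo sapiens) for inhibition, read by sulforhodamine B assay, with a stated time of 48 h, tested at 0.01 uM; a higher number here means a weaker effect of the compound at the concentration tested, a lower number a stronger effect. Compound 1 `COc1cc(Cl)cc(-c2nn(-c3cccc(NC(=O)Nc4ccc(Cl)c(C(F)(F)F)c4)c3)cc2-c2ccncc2)c1` gives 95%. Compound 2 `COc1cc(Cl)cc(-c2nn(-c3cccc(NC(=O)Nc4ccc(Cl)c(Cl)c4)c3)cc2-c2ccncc2)c1` gives 94%. Compound 3 `COc1cc(Cl)cc(-c2nn(-c3cccc(NC(=O)Nc4cccc(C(F)(F)F)c4)c3)cc2-c2ccncc2)c1` gives 89%. All three numbers lie close together: the move from compound 1 to compound 2 is a number 1 percentage points lower from compound 1 to compound 2 (within the scatter), from compound 1 to compound 3 it is a number 6 percentage points lower from compound 1 to compound 3 (within the scatter), and from compound 2 to compound 3 it is a number 5 percentage points lower from compound 2 to compound 3 (within the scatter). Compound 3 therefore stands at the low end of the three, but within the scatter of both others, so the three are best read as equal and all as weak at this concentration.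

Compound 4 `COc1cc(Cl)cc(-c2nn(-c3cccc(NC(=O)c4cccc(C(F)(F)F)c4)c3)cc2-c2ccncc2)c1` differs from compound 3 as follows: 3-(trifluoromethyl)phenyl in place of (3-(trifluoromethyl)phenyl)amino on a carbonyl carbon. Among the compounds with values here, none of the measured steps touches this part of the molecule; each of them changed only the substituents of the outer aromatic ring, and each stayed within the scatter. Within the data shown here, there is thus no measured step that bears directly on removing the amide-type nitrogen, and the only guide is that the series so far sits at a near-uniform level.

On that basis compound 4 is estimated at 93%, between 80% and 102%, an expected step of a number 4 percentage points higher from compound 3 to compound 4 (within the scatter) that would stay within the scatter.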

Compound 4, a percentage reported as activity, at one concentration (the size of the read-out at that concentration, not a potency): 57%
The estimate for compound 4 lay 36 percentage points above the measured number; measured number below the stated range.
By their numbers in this assay, from the lowest: compound 4; then compounds 3, 2 and 1 (each within the scatter of the next).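

In this assay, within the data shown here, the earlier steps changed only the substituents of the outer aromatic ring and stayed within the scatter, whereas this change acts on the link itself: 3-(trifluoromethyl)phenyl replaces (3-(trifluoromethyl)phenyl)amino on the carbonyl carbon, turning the urea into an amide (a number 32 percentage points lower from compound 3 to compound 4 (beyond the scatter)). Since a lower number means a stronger effect, this link matters far more at the tested concentration than the ring substituents compared so far, and the steps from the other two ureas, which also change those substituents, point the same way (a number 37 percentage points lower from compound 2 to compound 4 (beyond the scatter); a number 38 percentage points lower from compound 1 to compound 4 (beyond the scatter)). The group that leaves has a hydrogen-bond donor and the one that enters has none, but no measurement here explains why the number falls.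

As far as these compounds go, whether a methylene group or an oxygen atom in place of the lost nitrogen would behave like compound 3 or like compound 4 stays open, as does whether a 3,4-dichlorophenyl group directly on the carbonyl carbon would match compound 4. From the compounds shown here alone, a single concentration also shows only the size of the effect at that concentration, so how the effects of compound 3 and compound 4 compare at other concentrations remains unknown.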